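The compounds below may be only part of what the source reports. "The series", "measured", "known", "first", "only" and "open" are said of these compounds alone.

Measured compounds in this series:

compound 2 `O=C(CSc1ncccn1)N/N=c1/scc(-c2ccc(Br)cc2)n1-c1ccccc1` — > 200 ug/mL
compound 1 `Cn1nnnc1SCC(=O)N/N=c1/scc(-c2ccc(F)cc2)n1-c1ccccc1` — "not determined" (no result reported)

In a functional assay on C6 cells (Rattus norvegicus) for cytotoxicity, read by MTT assay, with a stated time of 24 h (a lower number here means a stronger inhibitor, a higher number a weaker inhibitor), compound 2 gives only a limit, > 200 ug/mL. Compound 1 has no number in this assay. What the data offer: the limit of > 200 ug/mL in this assay, at which 1 of the 2 values shown sits.

Compound 3 `O=C(CSc1ncccn1)N/N=c1/scc(-c2ccc(F)cc2)n1-c1ccccc1` differs from compound 2 by fluoro in place of bromo on an aromatic carbon. Among the measured compounds shown here, no measured pair shows this change, so no step beyond the scatter is expected in either direction. Compound 3 is therefore estimated at 200 ug/mL (100 ug/mL to 400 ug/mL), the expected step of a number no higher from compound 2 to compound 3 (the limit leaves the size open) being nothing beyond the scatter, and a limit again the likelier result.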

Compound 3, half-maximal inhibitory concentration: 110 ug/mL
Estimate against measurement, compound 3: 1.8-fold (0.26 log units) above; the measured number falls inside the stated range.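

With fluoro in place of bromo on the aromatic carbon para to a large group, the series gains its first single number: in this assay compound 3 gives 110 ug/mL. The change brings an at least 1.8-fold lower number from compound 2 to compound 3 (0.25 log units; that floor lies within the scatter), so the printed floor alone does not separate the two compounds, while the true size of the step may be larger. Compound 2 stands only as a limit: the limit of > 200 ug/mL in this assay, at which 1 of the 3 values shown sits.

On these data alone, whether chloro, methoxy or an amine at the same position would follow fluoro or bromo stays open. So does the effect of replacing the rest of the molecule while keeping 4-fluorophenyl.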